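Methyl for Ethynyl on the Shared Core

The source may hold more compounds than are shown below. What is called first, only, known or untested is meant among the compounds shown, and "the series" means these compounds.

Three compounds of the series carry numbers in an assay on HEK293 cells for agonist activity at Toll-like receptor 8 (Homo sapiens), read by spectrophotometry; a higher number here means that more compound is needed for the effect, a lower number that less compound is needed. Compound 1 `CCCCNc1nc(N)nc(C)c1CCCN1C(=O)c2ccccc2C1=O` gives 453 nM. Compound 2 `CCCCNc1nc(N)nc(C)c1CCCn1c(C)nc2ccccc21` gives 366 nM. Compound 3 `C#Cc1c(C)nc(N)nc1NCCCC` gives 4900 nM, the highest of the three numbers; its gap to compound 1 and its gap to compound 2 both lie beyond the scatter, so compound 3 is the least potent of the measured set. Compound 4 `CCCCNc1nc(N)nc(C)c1C` has not yet been measured in this assay.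

The change from compound 3 to compound 4 is methyl in place of ethynyl on an aromatic carbon. The site is an aromatic carbon of the six-membered aromatic ring with two nitrogen, ortho to the butylamino group and to a methyl group, para to the amino group. Going by the values given here, no step between two measured compounds differing in a single place exists, so the size of this step can only be guessed. Compound 1 and compound 2, which carry longer groups at this place, both give numbers far below that of compound 3. Methyl and ethynyl are small groups of nearly the same size, so a step expected to stay within or just beyond the scatter in this assay, with no strong pull in either direction, is the working assumption.

Compound 4 is therefore expected to give roughly 6000 nM in this assay. The expected range for compound 4 runs from 1500 nM to 25000 nM. The expected step of a 1.2-fold higher number from compound 3 to compound 4 (0.09 log units; within the scatter) is small.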

Compound 4, half-maximal effective concentration: 3280 nM
Estimate against measurement, compound 4: 1.8-fold (0.26 log units) above; the range from low to high includes it.
By their numbers in this assay, from the lowest: compounds 2 and 1 (each within the scatter of the next); then compounds 4 and 3 (each within the scatter of the next).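

In this assay the first step read directly at this aromatic carbon, a 1.5-fold lower number from compound 3 to compound 4 (0.17 log units; within the scatter), lies within the scatter, so ethynyl and methyl cannot be told apart here. The change removes one carbon and the triple bond outside aromatic rings, yet the number stays in the same range: compound 3 and compound 4 form one group, while compound 1 at 453 nM and compound 2 at 366 nM form another, with far lower numbers, so among the compounds shown only the two longer groups go with such numbers at this position. No measurement bears on this result, and the step comes with no account of its size.

Still open, on these data alone, is whether the low numbers of compound 1 and compound 2 follow from chain length alone or need the groups at the end of their chains, a question that a plain propyl chain at this aromatic carbon would address. Also open, as far as these compounds go, is how a group of about this small size but of another kind, such as an amine or a nitrile, would compare with methyl and ethynyl at the same place on the shared core.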